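From thian-4-yl to bromo on the shared core

The source may hold more compounds than are shown below. What is called first, only, known or untested is meant among the compounds shown, and "the series" means these compounds.

In a functional assay on the whole organism for inhibition, with Rattus norvegicus as the target (on this read-out lower numbers stand for an effect already at smaller amounts and higher numbers for an effect only at larger amounts of compound), compound 2 (`CC(Cc1ccc(Cl)cc1)(Oc1ccc(C2CCSCC2)cc1)C(=O)O`) gives < 10 mg/kg, which is a limit and not a number. Compound 1 (`CC(Cc1ccc(Cl)cc1)(Oc1ccc(Cc2ccc(Cl)cc2)cc1)C(=O)O`) gives > 10 mg/kg, which is also a limit. Compound 3 (`CC(Cc1ccc(Cl)cc1)(Oc1ccc(Br)cc1)C(=O)O`) differs from compound 2 by bromo in place of thian-4-yl on an aromatic carbon, with bromo in place of thian-4-yl on an aromatic carbon. Among the measured compounds shown here, the only measured step, a number no higher from compound 1 to compound 2 (the limit leaves the size open), has no readable size, and it is not the same change. A step of an at least 1.2-fold higher number from compound 2 to compound 3 (0.07 log units; that floor lies within the scatter) is expected, towards a higher number in this assay, though this estimate is loose. Compound 3 is estimated at 12 mg/kg, with an expected range of 3 mg/kg to 40 mg/kg.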

Compound 3, dose for half-maximal effect: < 1 mg/kg
Compound 3: only a limit was reported (the forecaster's own chance of this, stated with the estimate: 60%); at least 12-fold (1.07 log units) between middle value and limit.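

With bromo in place of 4-chlorobenzyl on an aromatic carbon para to a large group, this assay shows an at least 10-fold lower number from compound 1 to compound 3 (1.00 log units; beyond the scatter). A substituent with no ring is therefore enough at this position for an effect at small doses. The step from compound 2 to compound 3 cannot be read, and the value of compound 3 is itself a limit: the limit of < 1 mg/kg in this assay, at which 1 of the 3 values shown sits.

What number lies behind that limit stays open. So does whether chloro, methoxy or an amine at this position would go with a similar dose.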